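The compounds below may be only part of what the source reports. "The series", "measured", "known", "first", "only" and "open" are said of these compounds alone.

Measured compounds:
- Compound 1 `O=c1c(O)c(-c2ccccc2)oc2cc(OCc3ccccc3Cl)cc(O)c12`: in an ADME assay on Huh-5-2 cells (Homo sapiens) for cytotoxicity, read by WST assay, with a stated time of 3 days (on this read-out higher numbers stand for lower toxicity in this test and lower numbers for higher toxicity in this test), compound 1 gives > 100000 nM.
- Compound 2 `N#Cc1ccccc1COc1cc(O)c2c(=O)c(O)c(-c3ccccc3)oc2c1`: in this assay compound 2 gives 22000 nM.

The value for compound 1 is a limit of the assay and not a number; it sits at the limit of > 100000 nM in this assay, at which 1 of the 2 values shown sits. Compound 2 therefore stands as the only real number shown, the other value being a limit. Within the data shown here, the one measured step is an at least 4.5-fold lower number from compound 1 to compound 2 (0.65 log units; beyond the scatter). Compound 3 `O=c1c(O)c(-c2ccccc2)oc2cc(OCc3ccccc3[N+](=O)[O-])cc(O)c12` differs from compound 2 by nitro in place of cyano on an aromatic carbon. The measured step bears on this change only loosely: it swapped a different group at the same place, and it shows that such a swap can move the number at least modestly. Going by these compounds, whether replacing cyano with nitro does the same is unknown, so for compound 3 a step of modest size at most, in either direction, is expected in this assay, and quite possibly none beyond the scatter. Compound 3 is estimated at 22000 nM, with a range from 7000 nM to 70000 nM, which means an expected step of no change at the digits printed from compound 2 to compound 3 (within the scatter).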

Compound 3, half-maximal cytotoxic concentration: 32000 nM
Beside the measured number, compound 3's estimate is 1.5-fold (0.16 log units) below it; low and high end bracket the measured number.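

In this assay, nitro in place of the nitrile on this aromatic carbon, ortho to a large group, gives a 1.5-fold higher number from compound 2 to compound 3 (0.16 log units; within the scatter), so the two groups cannot be told apart in this test. The change from chloro to nitro gives an at least 3.1-fold lower number from compound 1 to compound 3 (0.49 log units; beyond the scatter), which means that the lower number, here standing for higher toxicity in this test, is not confined to the nitrile. The value of compound 1 is a limit and not a number, so the full size of the steps away from it stays unknown: the limit of > 100000 nM in this assay, at which 1 of the 3 values shown sits.

The compounds shown leave open whether an amine or a carboxylic acid at this place would also give a lower number than chloro. They also do not tell what separates chloro from the other two groups.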